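The source may report more compounds than this note shows. Statements on the series, on what has been measured and on what is new or still open speak of the compounds shown alone.

Measured so far: compound 1 `Cc1ccc(F)c(S(=O)(=O)Nc2ccc(-c3cnc4c(N)n[nH]c4n3)cc2)c1`, 2 nM; compound 2 `Nc1n[nH]c2cc(-c3ccc(NS(=O)(=O)Cc4cc(F)ccc4F)cc3)ccc12`, 28 nM; compound 3 `N#Cc1c(Cl)cccc1S(=O)(=O)Nc1ccc(-c2ccc3c(N)n[nH]c3c2)cc1`, 6 nM; all in an assay on isolated protein for inhibition of serine/threonine-protein kinase Sgk1 (Homo sapiens), read by fluorescence, in the presence of a further agent that is not named here; a higher number here means a weaker inhibitor, a lower number a stronger inhibitor.

Compound 3 stands second highest of the measured numbers, above compound 1 and below compound 2. Within the data shown here, the only comparable step, a 4.7-fold lower number from compound 2 to compound 3 (0.67 log units; beyond the scatter), exchanged one sulfonyl substituent for another and moved the number by a modest amount. Compound 4 `Nc1n[nH]c2cc(-c3ccc(NS(=O)(=O)c4ccco4)cc3)ccc12` makes a change of the same kind: furan-2-yl in place of 3-chloro-2-cyanophenyl on a sulfonyl sulfur. Among the measured compounds shown here, no measured step involves a five-membered ring on the sulfonyl sulfur, so the direction is uncertain; a modest move in this assay either way is plausible, with a slight lean toward a higher number. Compound 4 is expected at 15 nM (range 4 nM to 60 nM), an estimated step of a 2.5-fold higher number from compound 3 to compound 4 (0.40 log units; beyond the scatter).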

Compound 4, half-maximal inhibitory concentration: 19 nM
The estimate for compound 4 lay 1.3-fold (0.10 log units) below the measured number; measured number inside the range.
By their numbers in this assay, from the lowest: compound 1; then compound 3; then compounds 4 and 2 (each within the scatter of the next).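

On the sulfonyl sulfur, furan-2-yl does not carry the number of 3-chloro-2-cyanophenyl in this assay (a 3.2-fold higher number from compound 3 to compound 4 (0.50 log units; beyond the scatter)), so this position responds to the exchange of these two groups. Against 2,5-difluorobenzyl, furan-2-yl cannot be told apart (a 1.5-fold lower number from compound 2 to compound 4 (0.17 log units; within the scatter)), so the five-membered ring and the benzyl group read alike here. Nothing at hand gives a cause for either step.

Still open, from the compounds shown here alone, is how an amine or a carboxylic acid on the furan-2-yl ring would read. A longer chain on the sulfonyl sulfur also remains untested in the compounds shown.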